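The compounds below may be only part of what the source reports. "The series", "measured", "known", "first", "only" and "open" are said of these compounds alone.

Working notes on the series, continued. The series shares a core in which a sulfonylated ring amide carries an acetamide side chain to an amine; compound 1 is `COc1ccc2c(c1)CCCC2NC(=O)C[C@@H]1C(=O)NC=CN1S(=O)(=O)c1ccc(C)cc1` and compound 2 is `Cc1ccc(S(=O)(=O)N2C=CNC(=O)[C@H]2CC(=O)NC2CCNc3ccccc32)cc1`. In an in vitro functional assay on cells for antagonist activity at B1 bradykinin receptor (Homo sapiens), read by luminescence and calcium flux, with a stated time of 2 h (a higher number here means a weaker inhibitor, a lower number a stronger inhibitor), compound 1 gives 8.95 nM, and in the same assay compound 2 gives 21.6 nM. Compound 3, `CC1(C)CNCC[C@@H]1NC(=O)C[C@@H]1C(=O)NC=CN1S(=O)(=O)c1ccc(Cl)c(Cl)c1`, carries a 3,4-dichlorophenyl on the sulfonyl sulfur and a piperidine amine on the side chain; in this assay compound 3 gives 0.65 nM. That is the lowest of the three numbers, and both gaps, to compound 1 and to compound 2, lie beyond the scatter, so compound 3 is the strongest inhibitor among the measured compounds.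

The next compound is compound 4, `Cc1cc(S(=O)(=O)N2C=CNC(=O)[C@H]2CC(=O)N[C@H]2CCNCC2(C)C)c(C)cc1Cl`. It keeps the amine and the core of compound 3 and changes only the aryl on the sulfonyl sulfur: 4-chloro-2,5-dimethylphenyl in place of 3,4-dichlorophenyl on a sulfonyl sulfur. For the measured compounds named here, no step of this kind has been measured, so the expectation rests on compound 3 alone, with its value 0.65 nM as the anchor. A small change in either direction, or none beyond the scatter, is expected; in this assay the step of a 2.3-fold higher number from compound 3 to compound 4 (0.36 log units; beyond the scatter) is the estimated outcome. Compound 4 is expected to give 1.5 nM in this assay, within a range from 0.4 nM to 6 nM.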

Compound 4, half-maximal inhibitory concentration: 0.31 nM
The estimate for compound 4 lay 4.8-fold (0.68 log units) above the measured number; the whole stated range lies above it.
By their numbers in this assay, from the lowest: compound 4; then compound 3; then compound 1; then compound 2.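

For the compounds shown here, this is the first step in which only the aryl on a sulfonyl sulfur changes while the shared core and the amine side chain stay fixed: in this assay, 4-chloro-2,5-dimethylphenyl in place of 3,4-dichlorophenyl gives a 2.1-fold lower number from compound 3 to compound 4 (0.32 log units; beyond the scatter), a modest step beyond the scatter. The position therefore accepts the exchange of one chlorine for two methyl groups, with the larger aryl (9 heavy atoms against 8) retaining sub-nanomolar inhibition and the step running toward the stronger inhibitor. No measurement at hand bears on why the number falls with this exchange.

This single pair, read with one amine on the side chain, leaves open whether the same exchange would give a step of similar size with the amines of compound 1 or compound 2. It also leaves open which part of the new aryl, the chlorine or either methyl group, carries the step, and how a methoxy group or a pyridine ring would read at this position.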